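Swapping the sulfonamide amine in a urea series

The source may hold more compounds than are shown below. What is called first, only, known or untested is meant among the compounds shown, and "the series" means these compounds.

Three compounds share a urea linking a pyridine-type methylamine to an aryl sulfonyl group. Compound 1 `Cc1cncc(CNC(=O)Nc2ccc(S(=O)(=O)N3CCOCC3)cc2)c1` gives 40 nM in an assay on isolated protein for inhibition of Nicotinamide phosphoribosyltransferase (Homo sapiens), read by spectrophotometry, with stated times of 15 min and 30 min; a higher number here means a weaker inhibitor, a lower number a stronger inhibitor. Compound 2 `O=C(NCc1cnccn1)Nc1ccc(S(=O)(=O)c2ccccc2)cc1` gives 1300 nM in this assay. Compound 3 `O=C(NCc1cccnc1)Nc1ccc(S(=O)(=O)N2C3CCC2COC3)cc1` gives 10 nM in this assay, the lowest number of the three, with its nearest neighbour compound 1 lying beyond the usual scatter and compound 2 far further away.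

Compound 4 `O=C(NCc1cccnc1)Nc1ccc(S(=O)(=O)N[C@H]2CC[C@H](O)CC2)cc1` has not yet been measured. It differs from compound 3 in one place: a group of 8 heavy atoms (6 carbon, 1 nitrogen, 1 oxygen; one six-membered non-aromatic ring of carbon only) in place of a group of 8 heavy atoms (6 carbon, 1 nitrogen, 1 oxygen; one five-membered non-aromatic ring with 1 hetero atom, one six-membered non-aromatic ring with 2 hetero atoms), on a sulfonyl sulfur. Among the measured compounds shown here, with no measured pair showing this exact exchange, the expected step from compound 3 to compound 4 in this assay is a 2.0-fold higher number from compound 3 to compound 4 (0.30 log units; within the scatter), a small shift toward a higher number, not clearly beyond the scatter. Compound 4 is therefore estimated to give 20 nM in this assay, with a plausible range from 5 nM to 80 nM.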

Compound 4, half-maximal inhibitory concentration: 8 nM
Estimate against measurement, compound 4: 2.5-fold (0.40 log units) above; the measured number falls inside the stated range.
By their numbers in this assay, from the lowest: compounds 4 and 3 (each within the scatter of the next); then compound 1; then compound 2.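

On the sulfonyl sulfur, the two-ring group of compound 3 gives way to (4-hydroxycyclohexyl)amino with a 1.3-fold lower number from compound 3 to compound 4 (0.10 log units; within the scatter) in this assay, so the two compounds cannot be told apart in this assay. Among the compounds shown here, this pair shows that a group with one six-membered ring of carbon only and 2 hydrogen-bond donors can stand at this place with a number as low as that of a two-ring group with 0 donors, though it is only one pair. No measurement here explains this result.

The compounds shown leave open whether the hydroxyl matters, which a plain cyclohexylamino group or a ring carrying an amine or a carboxylic acid instead would test. They also leave open whether the opposite arrangement at the 2 defined stereocentres would give a similar number.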